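From 3-bromophenyl to 2,4-dimethylphenyl on the sulfonamide nitrogen

This account rests on a few compounds, and the source may have more. Where it says the series, first, only, none or still open, it means among the compounds named here.

In a functional assay on HT-29 cells (Homo sapiens) for antiproliferative activity, read by sulforhodamine B assay, with a stated time of 48 h (a lower number here means a stronger inhibitor, a higher number a weaker inhibitor), compound 1 (`O=C1NCCN1c1ccc(S(=O)(=O)Nc2ccc(F)cc2)cc1`) gives 370 nM and compound 2 (`O=C1NCCN1c1ccc(S(=O)(=O)Nc2ccc(F)c(F)c2)cc1`) gives 350 nM. Compound 3 (`O=C1NCCN1c1ccc(S(=O)(=O)Nc2cccc(Br)c2)cc1`) gives 77 nM, the lowest number of the three. Compound 4 (`Cc1ccc(NS(=O)(=O)c2ccc(N3CCNC3=O)cc2)c(C)c1`) has not yet been measured. It carries 2,4-dimethylphenyl in place of 3-bromophenyl on a sulfonamide nitrogen.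

The steps at this same place bear most directly on the change: a 4.8-fold lower number from compound 1 to compound 3 (0.68 log units; beyond the scatter) and a 4.5-fold lower number from compound 2 to compound 3 (0.66 log units; beyond the scatter), both modest. Fluoro in place of hydrogen on an aromatic carbon gave only a 1.1-fold lower number from compound 1 to compound 2 (0.02 log units; within the scatter). Going by the values given here, no measured compound carries 2,4-dimethylphenyl, so the data cover the entering group only indirectly. From the two modest steps, leaving 3-bromophenyl is expected to give a modest move to a higher number in this assay. The estimated change is a 2.9-fold higher number from compound 3 to compound 4 (0.46 log units; beyond the scatter). Compound 4 is estimated at 220 nM, with an expected range from 70 nM to 700 nM.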

Compound 4, half-maximal inhibitory concentration: 180 nM
Compound 4: middle estimate off by 1.2-fold (0.09 log units), on the high side, and the stated range covers the measured number.
By their numbers in this assay, from the lowest: compound 3; then compounds 4, 2 and 1 (each within the scatter of the next, the first and the last beyond it).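

In this assay, 2,4-dimethylphenyl shows that a phenyl group on the sulfonamide nitrogen carrying neither fluoro nor bromo can still give a lower number than 4-fluorophenyl, with a 2.1-fold lower number from compound 1 to compound 4 (0.31 log units; beyond the scatter), while the comparison with 3,4-difluorophenyl gives a 1.9-fold lower number from compound 2 to compound 4 (0.29 log units; within the scatter). 3-Bromophenyl nevertheless keeps the lowest number of the four, with a 2.3-fold higher number from compound 3 to compound 4 (0.37 log units; beyond the scatter), so the two methyl groups do not match it here. No measurement on hand accounts for these differences.

From the compounds shown here alone, how a single methyl group would compare with the two in 2,4-dimethylphenyl remains open, as does whether the bromine alone sets the number of compound 3. Also open, going by these compounds, is how a phenyl ring bearing a methoxy group, an amine or a carboxylic acid would behave at this nitrogen.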